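Aminophenyl for pyrrolidinyl in a tryptophan dioxygenase series

A few compounds are considered here, and "the series" means these few. Any claim that something is new, unique, unknown or untested is made for them only; others in the source may bear on it.

Compound 1 `FC(F)(F)c1cc(NC[C@H]2CCCN2)c2cn[nH]c2c1` gives 55% in an assay for inhibition of Tryptophan 2,3-dioxygenase (Homo sapiens), with stated times of 10 min and 60 min, tested at 10 uM (on this read-out higher numbers stand for a stronger effect at the one concentration tested and lower numbers for a weaker effect), the lower of the two numbers in hand. Compound 2 `COc1cc(CNc2cc(Br)cc3[nH]ncc23)c([N+](=O)[O-])cc1OC` gives 87% in this assay, a gap beyond the scatter. Compound 3 `Nc1cccc(CNc2cc(C(F)(F)F)cc3[nH]ncc23)c1` differs from compound 1 by 3-aminophenyl in place of pyrrolidin-2-yl on a saturated chain carbon bound to a nitrogen on an aromatic ring. Going by the values given here, no two measured compounds differ in one place, so the step has no direct precedent. Compound 2 carries an aromatic ring on a saturated chain carbon bound to a nitrogen on an aromatic ring and gives 87%, so an increase beyond the scatter is expected. The expected step is a number 17 percentage points higher from compound 1 to compound 3 (beyond the scatter). Compound 3 is estimated at 72%, with a range from 48% to 90%.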

Compound 3, a percentage reported as inhibition, at one concentration (the size of the read-out at that concentration, not a potency): 68%
Compound 3: middle estimate off by 4 percentage points, on the high side, and the stated range covers the measured number.
By their numbers in this assay, from the lowest: compound 1; then compound 3; then compound 2.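

In this assay, 3-aminophenyl in place of pyrrolidin-2-yl on a saturated chain carbon bound to a nitrogen on an aromatic ring gives a number 13 percentage points higher from compound 1 to compound 3 (beyond the scatter). This position therefore accepts a six-membered aromatic ring of carbon only, and the defined stereocentre of compound 1 is not needed to keep the read-out. No evidence on the cause of this step is in hand.

The compounds shown leave open what the amine on the ring contributes, a question that a plain phenyl or a 3-methoxyphenyl at this position would address. Compound 2 differs from compound 3 in more than one place, so it gives no direct reading on this change.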